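Moving a fluorine on the amide-linked ring

The compounds below may be only part of what the source reports. "The series", "measured", "known", "first", "only" and "open" are said of these compounds alone.

Compound 1 `CN1CCC(C(=O)N2Cc3c(NC(=O)C4CCC4)n[nH]c3C2(C)C)CC1`, compound 2 `CN1CCC(C(=O)N2Cc3c(NC(=O)c4cccs4)n[nH]c3C2(C)C)CC1` and compound 3 `CN1CCC(C(=O)N2Cc3c(NC(=O)c4cc(F)cc(F)c4)n[nH]c3C2(C)C)CC1` share one core and differ only in the group on the carbonyl carbon. In a physicochemical assay for solubility, at pH 7 (a higher number here means a more soluble compound, a lower number a less soluble compound), compound 1 reaches a limit of the assay, > 225000 nM. Compound 3 also reaches a limit in this assay, > 225000 nM. Compound 2 gives 155000 nM in this assay. The steps of an at least 1.4-fold lower number from compound 1 to compound 2 (0.16 log units; that floor lies within the scatter) and an at least 1.4-fold higher number from compound 2 to compound 3 (0.16 log units; that floor lies within the scatter) are both small, and a step that the two limits leave unreadable from compound 1 to compound 3; two of the three values sit at the limit of > 225000 nM in this assay, at which 2 of the 3 values shown sit.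

Compound 4 `CN1CCC(C(=O)N2Cc3c(NC(=O)c4ccc(F)c(F)c4)n[nH]c3C2(C)C)CC1` differs from compound 3 by 3,4-difluorophenyl in place of 3,5-difluorophenyl on a carbonyl carbon. For the measured compounds named here, no measured step exchanges one difluorophenyl for another, and the two readable steps, an at least 1.4-fold lower number from compound 1 to compound 2 (0.16 log units; that floor lies within the scatter) and an at least 1.4-fold higher number from compound 2 to compound 3 (0.16 log units; that floor lies within the scatter), are within the scatter. Compound 3 therefore offers only a floor, and the step is expected to be a number no higher from compound 3 to compound 4 (the limit leaves the size open). Compound 4 is expected to give 225000 nM in this assay, with a range from 120000 nM to 330000 nM.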

Compound 4, solubility: > 225000 nM
Compound 4: only a limit was reported; the forecaster's own chance of this, stated with the estimate: 60%; the middle value lies on the limit itself.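

In this assay compound 4 gives > 225000 nM, which is a limit of the assay and not a number. Set against the thiophen-2-yl group, the 3,4-difluorophenyl group gives an at least 1.4-fold higher number from compound 2 to compound 4 (0.16 log units; that floor lies within the scatter), a reading of the same kind as the one the 3,5-difluorophenyl group gave. The steps to compound 4 from compound 1 and from compound 3 cannot be read, so moving a fluorine on this ring shows no measurable change, and a second difluorophenyl arrangement on this carbonyl carbon now stands at the limit: the limit of > 225000 nM in this assay, at which 3 of the 4 values shown sit.

On these data alone, how compound 1, compound 3 and compound 4 truly compare remains open. Also open, as far as these compounds go, is whether a pyridine ring or a longer alkyl chain on this carbonyl carbon would give a readable value in this assay.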